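Benzyl Replaces Trifluoromethylphenyl: What to Expect for Compound 3

The source may hold more compounds than are shown below. What is called first, only, known or untested is meant among the compounds shown, and "the series" means these compounds.

Among the compounds with values here, compound 2 `Cc1ccc(S(=O)(=O)/N=C(/CCNC2=CC(=O)c3ccccc3C2=O)Nc2cccc(C(F)(F)F)c2)cc1` gives the highest of the two numbers measured so far: in a functional assay on DU-145 cells (Homo sapiens) for cytotoxicity, read by MTT assay, with a stated time of 48 h (a higher number here means a weaker inhibitor, a lower number a stronger inhibitor), compound 2 gives 84100 nM, while compound 1 `Cc1ccc(S(=O)(=O)/N=C(/CCNC2=CC(=O)c3ccccc3C2=O)Nc2ccc(Cl)cc2)cc1` gives 32400 nM. Within the data shown here, the one step recorded, a 2.6-fold higher number from compound 1 to compound 2 (0.41 log units; beyond the scatter), is therefore the only measured guide. Compound 3 `Cc1ccc(S(=O)(=O)/N=C(/CCNC2=CC(=O)c3ccccc3C2=O)NCc2ccccc2)cc1` differs from compound 2 by benzyl in place of 3-(trifluoromethyl)phenyl on an amine nitrogen. Among the measured compounds shown here, no measured pair shows this particular exchange, so the step from compound 1 to compound 2 bears on it only in that it shows the group on this amine nitrogen can shift the result by a modest amount. Compound 3 is expected to land near the value of compound 1 rather than beyond either end, which means an expected step of a 2.1-fold lower number from compound 2 to compound 3 (0.32 log units; beyond the scatter). The estimate for compound 3 is accordingly 40000 nM, with a range from 12000 nM to 150000 nM.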

Compound 3, half-maximal inhibitory concentration: 9120 nM
Beside the measured number, compound 3's estimate is 4.4-fold (0.64 log units) above it; measured number below the stated range.
By their numbers in this assay, from the lowest: compound 3; then compound 1; then compound 2.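

In this assay, benzyl on this amine nitrogen gives compound 3 the lowest number of the three, and it is the strongest inhibitor among them: the exchange gives a 9.2-fold lower number from compound 2 to compound 3 (0.96 log units; beyond the scatter) and, against the other aryl group, a 3.6-fold lower number from compound 1 to compound 3 (0.55 log units; beyond the scatter). Within the data shown here, the earlier pair had compared only two substituted phenyl groups, whereas these steps show that a benzyl group can also be carried here and that it outperforms both of them in this assay. Nothing measured here accounts for the gain.

The compounds shown leave open whether a longer chain, such as phenethyl, would lower the number further or raise it again. They also leave open whether a chlorine or a trifluoromethyl group on the benzyl ring would keep the gain seen with compound 3.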